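The compounds below may be only part of what the source reports. "The series", "measured", "known", "first", "only" and "open" are said of these compounds alone.

Compound 3 `NC(=O)c1c(NC(=O)c2ccccc2Br)sc2c1CCN(C(=S)Nc1ccccc1Br)C2` gives 17600 nM in a functional assay on HL-60 cells (Homo sapiens) for antiproliferative activity, with a stated time of 24 h (on this read-out lower numbers stand for stronger inhibition and higher numbers for weaker inhibition), the highest of the two numbers; the nearest is compound 1 `NC(=O)c1c(NC(=O)c2ccccc2Br)sc2c1CCN(C(=S)Nc1ccccc1Cl)C2` with 14600 nM, and a 1.2-fold higher number from compound 1 to compound 3 (0.08 log units; within the scatter). Compound 2 `NC(=O)c1c(NC(=O)c2ccccc2Br)sc2c1CCN(C(=S)Nc1ccccc1F)C2` sits at a limit, > 50000 nM. From it, an at least 2.8-fold lower number from compound 2 to compound 3 (0.45 log units; beyond the scatter), and an at least 3.4-fold higher number from compound 1 to compound 2 (0.53 log units; beyond the scatter), both beyond the scatter and both involving fluoro; the lone limit is the limit of > 50000 nM in this assay, at which 1 of the 3 values shown sits. Compound 4 `Cc1ccccc1NC(=S)N1CCc2c(sc(NC(=O)c3ccccc3Br)c2C(N)=O)C1` carries methyl in place of bromo on an aromatic carbon. Among the compounds with values here, no measured step swaps a halogen for methyl, so the only bearing is indirect: chloro and bromo sat within the scatter of each other, fluoro alone moved this assay. The step from compound 3 to compound 4 is expected to be about a 1.1-fold higher number from compound 3 to compound 4 (0.06 log units; within the scatter), no larger than the scatter. Compound 4 is therefore estimated at 20000 nM, within 8000 nM to 50000 nM.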

Compound 4, half-maximal inhibitory concentration: > 50000 nM
Compound 4: only a limit was reported (the forecaster's own chance of this, stated with the estimate: 25%); middle value at least 2.5-fold (0.39 log units) away from the limit.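

In this assay, methyl on this aromatic carbon does not match either halogen that gave a reading: an at least 2.8-fold higher number from compound 3 to compound 4 (0.45 log units; beyond the scatter), and an at least 3.4-fold higher number from compound 1 to compound 4 (0.53 log units; beyond the scatter). Compound 4 gives only a limit, as does compound 2, so the step between them cannot be read. Among the four compounds, readable values stand with chloro and bromo only, and fluoro and methyl both end at the same limit: the limit of > 50000 nM in this assay, at which 2 of the 4 values shown sit.

From the compounds shown here alone, whether a methoxy or an amino group on this aromatic carbon would give a reading remains open. So does whether any group here goes beyond compound 1 and compound 3.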